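The source may report more compounds than this note shows. Statements on the series, on what has been measured and on what is new or still open speak of the compounds shown alone.

For the measured compounds named here, compound 2 `COc1ccc(C(=O)/C=C/c2ccc([N+](=O)[O-])o2)cc1` gives 571000 nM in a toxicity assay on Vero cells (Chlorocebus sabaeus) for cytotoxicity (on this read-out higher numbers stand for lower toxicity in this test and lower numbers for higher toxicity in this test), the highest of the two numbers known, though the step of a 1.3-fold higher number from compound 1 to compound 2 (0.11 log units; within the scatter) from compound 1 `Cc1ccc(C(=O)/C=C/c2ccc([N+](=O)[O-])o2)cc1`, which gives 439000 nM, is within the scatter. Compound 3 `O=C(/C=C/c1ccc([N+](=O)[O-])o1)c1ccc(OCc2ccc(F)cc2)cc1` differs from compound 2 by 4-fluorophenyl in place of hydrogen on a saturated chain carbon bound to an oxygen on an aromatic ring. Going by the values given here, the only measured step, from methyl to methoxy, stayed within the scatter and does not cover an addition of this size, so no firm direction can be drawn from it. Compound 3 is therefore expected to sit near compound 2, with a step of a 2.3-fold lower number from compound 2 to compound 3 (0.36 log units; beyond the scatter) that may go either way, and its estimated value is 250000 nM in this assay, between 50000 nM and 900000 nM.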

Compound 3, half-maximal cytotoxic concentration: 430000 nM
Compound 3: middle estimate off by 1.7-fold (0.24 log units), on the low side, and the stated range covers the measured number.
By their numbers in this assay, from the lowest: compounds 3, 1 and 2 (each within the scatter of the next).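

In this assay, the addition of 4-fluorophenyl on a saturated chain carbon bound to an oxygen on an aromatic ring gives a 1.3-fold lower number from compound 2 to compound 3 (0.12 log units; within the scatter), so at this position a group of this size leaves the number within the scatter. Replacing the methyl group outright likewise gives a 1.0-fold lower number from compound 1 to compound 3 (0.01 log units; within the scatter). Nothing available here bears on the reason for this. The compounds shown leave open whether a chain carrying an amine or a carboxylic acid on this oxygen would also stay within the scatter of compound 2.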